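The source may hold more compounds than are shown below. What is called first, only, known or untested is meant among the compounds shown, and "the series" means these compounds.

Compound 3 `OC[C@H]1OC(n2cnc3c(-c4ccccn4)ncnc32)[C@H](O)[C@@H]1O` stands second highest of the three numbers measured in a functional assay on HL-60 cells (Homo sapiens) for inhibition; a lower number here means a stronger inhibitor, a higher number a weaker inhibitor: compound 3 gives 5600 nM, close to compound 1 `Cc1ccsc1-c1ncnc2c1ncn2C1O[C@H](CO)[C@@H](O)[C@H]1O`, which gives 4500 nM, and furthest from compound 2 `Cn1cccc1-c1ncnc2c1ncn2C1O[C@H](CO)[C@@H](O)[C@H]1O`, which gives 15700 nM. The step of a 1.2-fold higher number from compound 1 to compound 3 (0.09 log units; within the scatter) lies within the scatter, whereas a 2.8-fold lower number from compound 2 to compound 3 (0.45 log units; beyond the scatter) and a 3.5-fold higher number from compound 1 to compound 2 (0.54 log units; beyond the scatter) both lie beyond it. Compound 4 `OC[C@H]1OC(n2cnc3c(-c4ccoc4)ncnc32)[C@H](O)[C@@H]1O` differs from compound 3 in one place: furan-3-yl in place of pyridin-2-yl on an aromatic carbon. The measured steps bear only loosely on this change. Exchanging 3-methylthiophen-2-yl for pyridin-2-yl, a 1.2-fold higher number from compound 1 to compound 3 (0.09 log units; within the scatter), changed little, while the 1-methyl-1H-pyrrol-2-yl group of compound 2 gave the highest number of the three. Furan-3-yl matches none of these groups exactly, so the step of a 1.3-fold higher number from compound 3 to compound 4 (0.10 log units; within the scatter) is expected to be small, if anything toward a higher number. Compound 4 is therefore estimated at 7000 nM in this assay, with a range from 3000 nM to 18000 nM.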

Compound 4, half-maximal inhibitory concentration: 3300 nM
For compound 4 the middle estimate is 2.1-fold (0.33 log units) above the measured one; the range from low to high includes it.
By their numbers in this assay, from the lowest: compounds 4, 1 and 3 (each within the scatter of the next); then compound 2.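

At this position, furan-3-yl in place of pyridin-2-yl gives a 1.7-fold lower number from compound 3 to compound 4 (0.23 log units; within the scatter), and furan-3-yl in place of 3-methylthiophen-2-yl gives a 1.4-fold lower number from compound 1 to compound 4 (0.13 log units; within the scatter), so in this assay compound 1, compound 3 and compound 4 cannot be told apart, although their rings differ in size and hetero atom. Furan-3-yl in place of 1-methyl-1H-pyrrol-2-yl gives a 4.8-fold lower number from compound 2 to compound 4 (0.68 log units; beyond the scatter), which shows that a five-membered aromatic ring on this carbon does not in itself go with the higher number of compound 2. Nothing given here explains why compound 2 stands apart. The compounds shown leave open whether an unsubstituted phenyl ring, an amine or a longer alkyl chain on this carbon would stay level with compound 4. They also leave open whether a furan-2-yl group would do the same.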